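The source may hold more compounds than are shown below. What is called first, only, known or untested is meant among the compounds shown, and "the series" means these compounds.

Compound 1 `COc1ccc(-c2cccc3c(Cl)c(Br)c(C(F)(F)F)nc23)cc1` gives > 300000 nM in an assay for inhibition of ectonucleoside triphosphate diphosphohydrolase 8 (Homo sapiens), read by malachite green, with a stated time of 10 min; a higher number here means a weaker inhibitor, a lower number a stronger inhibitor.
Compound 2 `FC(F)(F)c1ccc(-c2cccc3c(Cl)c(Br)c(C(F)(F)F)nc23)cc1` gives > 300000 nM in this assay.

The value for compound 1 is a limit of this assay, not a number. The value for compound 2 is likewise a limit. The change from compound 1 to compound 2, trifluoromethyl in place of methoxy on an aromatic carbon, gives a step that the two limits leave unreadable from compound 1 to compound 2. It shows nothing about how far either compound lies from a readable inhibition. The only firm point is the limit of > 300000 nM in this assay, at which 2 of the 2 values shown sit, which tells that neither compound inhibits within the measurable range.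

Compound 3 `FC(F)(F)c1nc2c(-c3ccsc3)cccc2c(Cl)c1Br` differs from compound 1 by thiophen-3-yl in place of 4-methoxyphenyl on an aromatic carbon. Among the compounds with values here, no measured step involves a thiophen-3-yl group, so the expectation can rest only on the fact that both measured compounds sit at the limit. The shared core with a 4-methoxyphenyl or a 4-trifluoromethylphenyl group shows no inhibition, and a smaller aromatic group is not expected to change that. The expected step is a number no higher from compound 1 to compound 3 (the limit leaves the size open), meaning no change that reaches a readable value. For compound 3 the estimate is 300000 nM, with a range from 100000 nM to 1000000 nM.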

Compound 3, half-maximal inhibitory concentration: > 300000 nM
Compound 3: a limit, no number (the forecaster's own chance of this, stated with the estimate: 85%); the middle value sits exactly at the limit.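

Compound 1, compound 2 and compound 3 all end at a limit rather than a number, so no step between compound 1 and compound 3 can be read: the limit of > 300000 nM in this assay, at which 3 of the 3 values shown sit.

The compounds shown leave open whether any change to the shared core would give a readable inhibition, and how large such a change would need to be.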